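The source may report more compounds than this note shows. Statements on the series, on what has been measured and on what is new or still open speak of the compounds shown alone.

Measured so far in an ADME assay on a cell-free system (plasma, Homo sapiens) for metabolic stability, read by LC-MS, with a stated time of 60 min, at 37 degrees C, tested at 50 uM; on this read-out lower numbers stand for a less stable compound and higher numbers for a more stable compound:
- compound 1 `CCCCOC(=O)C1=C(S[C@@H]2CN[C@H](C(=O)Nc3cccc(C(=O)OCCCC)c3)C2)[C@H](C)[C@@H]2[C@@H]([C@@H](C)O)C(=O)N12`: 1%
- compound 2 `CC(C)C(=O)OCOC(=O)C1=C(S[C@@H]2CN[C@H](C(=O)Nc3cccc(C(=O)O)c3)C2)[C@H](C)[C@@H]2[C@@H]([C@@H](C)O)C(=O)N12`: 15%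
- compound 3 `CC(C)C(=O)OCOC(=O)C1=C(S[C@@H]2CN[C@H](C(=O)Nc3cccc(C(=O)OCOC(=O)C(C)C)c3)C2)[C@H](C)[C@@H]2[C@@H]([C@@H](C)O)C(=O)N12`: 8%

Compound 3 stands second highest of the three, and its gaps to compound 1 and to compound 2 both lie within the scatter, so the three cannot be ordered. Compound 4 `CC(C)C(=O)OCOC(=O)c1cccc(NC(=O)[C@@H]2C[C@H](SC3=C(C(=O)O)N4C(=O)[C@H]([C@@H](C)O)[C@H]4[C@H]3C)CN2)c1` differs from compound 3 by hydrogen in place of ((isopropylcarbonyl)oxy)methyl on an oxygen next to a carbonyl group. Within the data shown here, the one step that bears on this kind of change is a number 7 percentage points lower from compound 2 to compound 3 (within the scatter), where the same group was added to the other oxygen of this type; it was within the scatter. A change of similar size, going the opposite way, is therefore expected: a number 3 percentage points higher from compound 3 to compound 4 (within the scatter). Compound 4 is estimated at 11%, between 2% and 25%.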

Compound 4, percent of the compound remaining: 26%
For compound 4 the middle estimate is 15 percentage points below the measured one, and the stated range ends below it.
By their numbers in this assay, from the lowest: compounds 1, 3 and 2 (each within the scatter of the next, the first and the last beyond it); then compound 4.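

With hydrogen in place of ((isopropylcarbonyl)oxy)methyl on this oxygen, this assay gives a number 18 percentage points higher from compound 3 to compound 4 (beyond the scatter), so the change can be read at this position. The earlier step on the other oxygen of this type, a number 7 percentage points lower from compound 2 to compound 3 (within the scatter), could not show this. Nothing available explains why the result at this position reads as it does. Still open, as far as these compounds go, is how a methyl or an ethyl group on this same oxygen would read in this assay, and whether an amide in place of the ester would behave like the carboxy group.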